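This account rests on a few compounds, and the source may have more. Where it says the series, first, only, none or still open, it means among the compounds named here.

In a functional assay on the whole organism (strain Wistar) for inhibition, with Rattus norvegicus as the target, read by paw edema, with a stated time of 30 min, at a dose of 10 mg/kg by the intraperitoneal route (on this read-out higher numbers stand for more inhibition at the one dose given (going by the name of the read-out) and lower numbers for less inhibition), compound 1 `O=C(N/N=C/c1ccccc1)c1cccnc1Nc1cccc(C(F)(F)F)c1` gives 60.4%, and compound 2 `O=C(N/N=C/c1cccc(Cl)c1)c1cccnc1Nc1cccc(C(F)(F)F)c1` gives 77.8%. The two differ by chloro in place of hydrogen on an aromatic carbon, and that change brought a number 17.4 percentage points higher from compound 1 to compound 2 (beyond the scatter).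

Compound 3 `CNc1ncccc1C(=O)N/N=C/c1ccccc1` carries a different core; the difference between the two cores is not broken down here. In this assay compound 3 gives 56.5%, a number within the scatter of compound 1.

Compound 4 `CNc1ncccc1C(=O)N/N=C/c1cccc(Cl)c1` is not yet measured. It differs from compound 3 by chloro in place of hydrogen on an aromatic carbon, the same kind of change seen from compound 1 to compound 2. Because that earlier change gave a number 17.4 percentage points higher from compound 1 to compound 2 (beyond the scatter), a step of similar size is expected here, namely a number 13.5 percentage points higher from compound 3 to compound 4 (beyond the scatter). On that basis compound 4 is estimated to reach about 70% in this assay.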

Compound 4, a percentage reported as inhibition, in the whole organism at one dose (the size of the read-out at that dose, not a potency): 67.1%
Beside the measured number, compound 4's estimate is 2.9 percentage points above it; the measured number falls inside the stated range.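

Chloro in place of hydrogen on the aromatic ring gave a number 10.6 percentage points higher from compound 3 to compound 4 (beyond the scatter) in this assay on the core of compound 3, so the change raised the number on both cores shown. The two steps point the same way and cannot be told apart in size: the same change on two cores in this assay, a number 17.4 percentage points higher (beyond the scatter) from compound 1 to compound 2 and a number 10.6 percentage points higher (beyond the scatter) from compound 3 to compound 4, 6.8 percentage points apart, within the scatter of two such steps. This rests on just two pairs of compounds at a single dose, so it does not show that the change would carry over to any other core or that the two steps are truly equal.

The compounds shown leave open what chloro would do at other places on that ring. They also leave open what a different group there, such as an amine, a methoxy group or a carboxylic acid, would give.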